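The source may hold more compounds than are shown below. What is called first, only, known or untested is meant among the compounds shown, and "the series" means these compounds.

Measured so far:
compound 1 `COc1cc2ncnc(NNC(=S)NC(=O)c3ccc(C(F)(F)F)cc3)c2cc1OC`: 16800 nM
compound 2 `O=C(NC(=S)NNc1ncnc2ccccc12)c1ccc(C(F)(F)F)cc1`: 8050 nM

Both have been tested in a functional assay on MCF7 cells (Homo sapiens) for cytotoxicity, read by MTT assay, with a stated time of 72 h; a higher number here means a weaker inhibitor, a lower number a stronger inhibitor. Compound 1 gives 16800 nM in this assay, the higher of the two numbers. Compound 2 gives 8050 nM, a lower number that lies beyond the usual scatter, so compound 2 reads as the stronger inhibitor of the pair. Going by the values given here, no two measured compounds differ in a single place, so no step size is known from this series.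

The next compound, compound 3 `COc1cc2ncnc(NNC(=S)NC(=O)c3ccccc3)c2cc1OC`, differs from compound 1 as follows: hydrogen in place of trifluoromethyl on an aromatic carbon The trifluoromethyl leaves and a hydrogen enters on an aromatic carbon of the six-membered aromatic ring of carbon only. Among the compounds with values here, the series holds no measured step for a change of this kind, and the two values at hand say nothing about it. The expected step of a 1.2-fold higher number from compound 1 to compound 3 (0.08 log units; within the scatter) is therefore small, with no clear direction and probably within the scatter. Compound 3 is estimated at 20000 nM in this assay, with a range from 8000 nM to 50000 nM.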

Compound 3, half-maximal inhibitory concentration: 6990 nM
The estimate for compound 3 lay 2.9-fold (0.46 log units) above the measured number; the measured number lies below the stated range.
By their numbers in this assay, from the lowest: compounds 3 and 2 (each within the scatter of the next); then compound 1.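

In this assay, going by these compounds alone, the change from 4-(trifluoromethyl)phenyl to phenyl, made on an aromatic carbon para to a large group, gives a 2.4-fold lower number from compound 1 to compound 3 (0.38 log units; beyond the scatter) as a modest step and the only single-place step available so far. On the core of compound 1, the trifluoromethyl at this position is therefore not required for cytotoxicity in this cell assay, since the compound carrying hydrogen there gives the lower number. The two compounds show only that this one replacement lowers the number, and no measurement on hand accounts for the size or direction of the step.

From the compounds shown here alone, two compounds define this position, so it remains open whether the trend is graded or whether other replacements, such as a methyl, a chlorine, a methoxy or an amine, would read closer to hydrogen or to trifluoromethyl. Going by these compounds, it is also open whether the same replacement gives a step of similar size and direction on the core of compound 2, whose two-place difference from compound 3 permits no direct comparison.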